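This account rests on a few compounds, and the source may have more. Where it says the series, first, only, none or still open, it means among the compounds named here.

In an ADME assay on microsomes from liver (Canis lupus familiaris) for metabolic stability (a lower number here means that the compound disappears faster, a higher number that the compound lasts longer), the measured compounds read as follows:

- compound 1 `Nc1nc(NCCNc2ncc(-c3ncc[nH]3)c(-c3ccc(Cl)cc3)n2)ccc1[N+](=O)[O-]` gives > 0.5 h as a limit
- compound 2 `Nc1nc(NCCNc2ncc(-c3ncc[nH]3)c(-c3ccc(C(F)(F)F)cc3)n2)ccc1[N+](=O)[O-]` gives > 0.5 h as a limit
- compound 3 `Nc1nc(NCCNc2ncc(-c3ncc[nH]3)c(-c3ccc(F)cc3F)n2)ccc1[N+](=O)[O-]` gives > 0.5 h as a limit

Compound 3 stands at > 0.5 h as a limit and not as a number. Among the measured compounds shown here, the series so far offers only the limit of > 0.5 h in this assay, at which 3 of the 3 values shown sit, and no measured number to place it against.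

Compound 4 `Nc1nc(NCCNc2ncc(-c3ncc[nH]3)c(-c3cc(F)ccc3F)n2)ccc1[N+](=O)[O-]` has the same atoms as compound 3, joined differently, with 2,5-difluorophenyl in place of 2,4-difluorophenyl on an aromatic carbon at the same place on the shared core.

The measured steps that bear on this place are a step that the two limits leave unreadable from compound 1 to compound 3 and a step that the two limits leave unreadable from compound 2 to compound 3 and also a step that the two limits leave unreadable from compound 1 to compound 2 in the same group. For the measured compounds named here, none of these has a readable size, and no measured compound carries 2,5-difluorophenyl. No step beyond the scatter is therefore expected, and no direction can be given. The expected step is a step that the limit leaves unreadable from compound 3 to compound 4 in this assay as an estimate resting on this thin basis. A further limit is the most likely report for compound 4 in this read-out.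

The estimate for compound 4 is 0.7 h with an expected range from 0.4 h to 1.3 h in this assay as the working figure.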

Compound 4, half-life: > 0.5 h
Compound 4: a limit, no number (the forecaster's own chance of this, stated with the estimate: 80%); the middle value is on the limit's open side.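

In this assay compound 4 gives > 0.5 h, a limit and not a number. No step from compound 1, compound 2 or compound 3 to compound 4 can be read, as the series holds only one limit: the limit of > 0.5 h in this assay, at which 4 of the 4 values shown sit.

As far as these compounds go, the actual half-lives of all four compounds, and any ranking among the three aryl changes, remain open.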